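Permeability notes: compound 3 to compound 4

A few compounds are considered here, and "the series" means these few. Any claim that something is new, unique, unknown or untested is made for them only; others in the source may bear on it.

Measured so far in an ADME assay for permeability, using PAMPA; a higher number here means that the compound crosses the layer faster, a lower number that the compound crosses the layer more slowly:
- compound 1 `CC1(C)C[C@H](c2c[nH]c3c(C(N)=O)cc(-c4ccc(F)cc4)cc23)CCS1(=O)=O`: 283 nm/s
- compound 2 `NC(=O)c1cc(-c2ccccc2)cc2c(C3CCS(=O)(=O)CC3)c[nH]c12`: 277 nm/s
- compound 3 `CCN(CC)CCCS(=O)(=O)N1CCC(c2c[nH]c3c(C(N)=O)cc(-c4ccccc4)cc23)CC1`: 200 nm/s

Compound 3 holds the lowest of the three numbers in this assay, yet its gap to compound 2 and its gap to compound 1 both lie within the usual scatter, so the three compounds cannot be put in any order on these data. Among the measured compounds shown here, no pair of measured compounds differs in one place only, so no measured step is available to guide the next change.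

Compound 4 `NC(=O)c1cc(-c2ccccc2)cc2c(C3CCN(S(=O)(=O)CCCN4CCCCC4)CC3)c[nH]c12` is not yet measured in this assay. It differs from compound 3 in one place: piperidin-1-yl in place of diethylamino on a saturated chain carbon, three bonds along the chain from a sulfonyl sulfur. The group that leaves and the group that enters each carry one hydrogen-bond acceptor and no donor, with no net charge, and the place on the chain is unchanged.

With nothing measured for such a change, the expected step of a 1.1-fold higher number from compound 3 to compound 4 (0.03 log units; within the scatter) is none beyond the scatter. Compound 4 is therefore estimated at 215 nm/s in this assay, within 120 nm/s to 380 nm/s.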

Compound 4, apparent permeability: 240 nm/s
For compound 4 the middle estimate is 1.1-fold (0.05 log units) below the measured one; measured number inside the range.
By their numbers in this assay, from the lowest: compounds 3, 4, 2 and 1 (each within the scatter of the next).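

In this assay, among the compounds shown here, the first one-place comparison in the set gives a 1.2-fold higher number from compound 3 to compound 4 (0.08 log units; within the scatter), so piperidin-1-yl in place of diethylamino on a saturated chain carbon, three bonds along the chain from a sulfonyl sulfur, leaves the read-out unchanged as far as the scatter can tell. The earlier compounds shown here offered no such reading: this place now carries either an open diethylamino group or a six-membered non-aromatic ring with no step beyond the scatter. No measurement at hand bears on the reason for this result.

On these data alone, whether morpholin-4-yl, a primary amine or a carboxylic acid at this place would behave in the same way remains open, as does the outcome with a longer chain to the sulfonyl sulfur. The compounds shown also leave open whether any change at this place can produce a step beyond the scatter.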